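Aryl change from compound 3 to compound 4

The source may hold more compounds than are shown below. What is called first, only, known or untested is meant among the compounds shown, and "the series" means these compounds.

In a functional assay on A549 cells (Homo sapiens) for inhibition, read by MTT assay, with a stated time of 24 h (on this read-out higher numbers stand for weaker inhibition and lower numbers for stronger inhibition), compound 1 `CC1(C)[C@H]2CC[C@]1(C)N(Cc1cn(-c3ccccc3C#N)nn1)C(=O)C2` gives 100 nM and compound 2 `CC1(C)[C@H]2CC[C@]1(C)N(Cc1cn(-c3cccc(Cl)c3)nn1)C(=O)C2` gives 60 nM on the same core, a gap that stays within the scatter (a 1.7-fold lower number from compound 1 to compound 2 (0.22 log units; within the scatter)). Compound 3 `COc1ccccc1-n1cc(CN2C(=O)C[C@@H]3CC[C@@]2(C)C3(C)C)nn1` stands highest of the three at 350 nM on this read-out, beyond the scatter from both others. Still unmeasured is compound 4 `Cc1ccc(-n2cc(CN3C(=O)C[C@@H]4CC[C@@]3(C)C4(C)C)nn2)cc1`, which carries 4-methylphenyl in place of 2-methoxyphenyl on an aromatic nitrogen.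

Within the data shown here, two measured steps bear on this change, both modest and beyond the scatter, and both arrive at 2-methoxyphenyl (a 3.5-fold higher number from compound 1 to compound 3 (0.54 log units; beyond the scatter)) and (a 5.8-fold higher number from compound 2 to compound 3 (0.77 log units; beyond the scatter)). Among these three compounds the 2-methoxyphenyl group goes with the highest number, and none of the three goes against this. None of them carries 4-methylphenyl, so the size of the change remains uncertain. A move toward a lower number in this assay is expected, of about the size of those two steps or somewhat smaller. The estimated step is a 2.7-fold lower number from compound 3 to compound 4 (0.43 log units; beyond the scatter) and no change at all is not excluded. The estimated value for compound 4 in this assay is 130 nM with an expected span from 45 nM to 380 nM for repeated measurements.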

Compound 4, half-maximal inhibitory concentration: 400 nM
For compound 4 the middle estimate is 3.1-fold (0.49 log units) below the measured one; measured number outside the range, above it.
By their numbers in this assay, from the lowest: compounds 2 and 1 (each within the scatter of the next); then compounds 3 and 4 (each within the scatter of the next).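

Swapping the aryl group on the aromatic nitrogen for 4-methylphenyl leaves the read-out in this assay unresolved from that of the 2-methoxyphenyl compound (a 1.1-fold higher number from compound 3 to compound 4 (0.06 log units; within the scatter)), so the two groups cannot be told apart at this position in this assay. The earlier compounds shown here left the highest number attached to 2-methoxyphenyl alone, but it is now shared by a second aryl group with a different substituent at a different ring position, and 4-methylphenyl also stands clearly apart from 3-chlorophenyl (a 6.7-fold higher number from compound 2 to compound 4 (0.82 log units; beyond the scatter)) and from 2-cyanophenyl (a 4.0-fold higher number from compound 1 to compound 4 (0.60 log units; beyond the scatter)). The four compounds therefore fall into two pairs on the shared core, and nothing available here accounts for that split.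

Among these compounds, each substituent appears at only one ring position, so these compounds cannot separate the identity of the substituent from its placement; 2-methylphenyl, 4-methoxyphenyl, 4-chlorophenyl and 4-cyanophenyl would be the direct comparisons. Also open, as far as these compounds go, is how this position responds to an unsubstituted phenyl or to a phenyl ring carrying an amine or a carboxylic acid.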